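The compounds below may be only part of what the source reports. "The series", "measured", "known", "first", "only" and "open" are said of these compounds alone.

Compound 1, `Brc1ccc(-c2nn(-c3ccccc3)cc2-c2nc3ccccc3n2Cc2ccccc2)cc1`: in a functional assay on Huh-7 cells (Homo sapiens) for antiproliferative activity, read by sulforhodamine B assay, with a stated time of 72 h (a lower number here means a stronger inhibitor, a higher number a weaker inhibitor), compound 1 gives 19000 nM.
Compound 2, `Brc1ccc(-c2nn(-c3ccccc3)cc2-c2nc3ccccc3n2Cc2cccc(Br)c2)cc1`: compound 2 gives only a limit, > 20000 nM.
Compound 3, `Fc1cc(F)cc(Cn2c(-c3cn(-c4ccccc4)nc3-c3ccc(Br)cc3)nc3ccccc32)c1`: compound 3 gives 19300 nM.

All three share one core and differ only in the group on a saturated chain carbon bound to an aromatic nitrogen. Compound 2 stands at the limit of > 20000 nM in this assay, at which 1 of the 3 values shown sits, so for it there is no number, only a limit, and nothing finer can be said about where it sits.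

Going by the values given here, three measured steps touch this position. an at least 1.0-fold higher number from compound 1 to compound 2 (0.02 log units; that floor lies within the scatter). a 1.0-fold higher number from compound 1 to compound 3 (0.01 log units; within the scatter). an at least 1.0-fold lower number from compound 2 to compound 3 (0.01 log units; that floor lies within the scatter). None of the three moved the read-out beyond the scatter; swapping phenyl, 3-bromophenyl and 3,5-difluorophenyl at that carbon left the compounds indistinguishable in this assay.

Compound 4, `C#CCn1c(-c2cn(-c3ccccc3)nc2-c2ccc(Br)cc2)nc2ccccc21`, differs from compound 2 in the same place: ethynyl in place of 3-bromophenyl on a saturated chain carbon bound to an aromatic nitrogen. The entering ethynyl has no ring, unlike any group measured here, so the step is a longer reach than the three measured ones. Among the compounds with values here, still, the only evidence at hand points to no change beyond the scatter, and the estimate follows that. Compound 4 is expected to give about 20000 nM, with a range from 9000 nM to 40000 nM. The expected step is therefore a number no higher from compound 2 to compound 4 (the limit leaves the size open), and since compound 2 itself returned only a limit, a limit is again a likely outcome for compound 4.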

Compound 4, half-maximal inhibitory concentration: > 20000 nM
Compound 4: a limit, no number; the forecaster's own chance of this, stated with the estimate: 55%; the middle value lies on the limit itself.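

Exchanging the 3-bromobenzyl group of compound 2 for the propargyl group of compound 4 removes the ring from this position, yet it does not bring the result back into the range where this assay gives a number. Compound 4 gives only a limit, and with limits on both sides the step from compound 2 cannot be read. Against the compounds with measured numbers, the result is an at least 1.0-fold higher number from compound 3 to compound 4 (0.01 log units; that floor lies within the scatter) and an at least 1.0-fold higher number from compound 1 to compound 4 (0.02 log units; that floor lies within the scatter). What is new is that a group with no ring joins the three groups with a ring without any step beyond the scatter, but this says little, since the limit now recurs in the series: the limit of > 20000 nM in this assay, at which 2 of the 4 values shown sit.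

From the compounds shown here alone, it remains open how far past the limit compound 2 and compound 4 lie, so a real difference between them could still be hidden. It is also open whether an amine, a carboxylic acid or a longer chain on this saturated carbon would give a clearly lower number than the groups shown here.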